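The compounds below may be only part of what the source reports. "The series", "measured", "known", "first", "only" and "open" are said of these compounds alone.

Compound 3 `Fc1cccc(F)c1Cc1cnc(Nc2ccc(COc3ccncc3)cc2)o1` in an ADME assay on MT2 cells (Homo sapiens) for cytotoxicity, read by MTT assay (a higher number here means that more compound is tolerated, a lower number that less compound is tolerated), gives > 100000 nM, which is a limit of the assay rather than a number. Compound 1 `CSCc1ccc(Nc2ncc(Cc3c(F)cccc3F)o2)cc1` likewise gives > 100000 nM, again a limit. Among the measured compounds shown here, compound 2 `N#Cc1ccc(Nc2ncc(Cc3c(F)cccc3F)o2)cc1` gives 7400 nM, the only number among the three; an at least 13-fold lower number from compound 1 to compound 2 (1.13 log units; beyond the scatter) and an at least 13-fold higher number from compound 2 to compound 3 (1.13 log units; beyond the scatter), while a step that the two limits leave unreadable from compound 1 to compound 3. Two of the three values sit at the limit of > 100000 nM in this assay, at which 2 of the 3 values shown sit. Compound 4 `OCCc1ccc(Nc2ncc(Cc3c(F)cccc3F)o2)cc1` carries hydroxymethyl in place of (pyridin-4-yl)oxy on a saturated chain carbon bound to an aromatic carbon. For the measured compounds named here, no measured step exchanges a hydroxymethyl, so none bears directly on this change; the two large steps both concern a cyano group. Compound 4 is therefore expected to remain near the limit, and the expected step is a number no higher from compound 3 to compound 4 (the limit leaves the size open). The estimate for compound 4 in this assay is 100000 nM, between 30000 nM and 300000 nM.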

Compound 4, half-maximal cytotoxic concentration: 35000 nM
For compound 4 the middle estimate is 2.9-fold (0.46 log units) above the measured one; the range from low to high includes it.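

On a saturated chain carbon bound to an aromatic carbon, hydroxymethyl, unlike methylsulfanyl or (pyridin-4-yl)oxy, brings a measured number into this assay, with an at least 2.8-fold lower number from compound 3 to compound 4 (0.45 log units; beyond the scatter) and an at least 2.8-fold lower number from compound 1 to compound 4 (0.45 log units; beyond the scatter). Compound 1 and compound 3 both remain limits of the assay: the limit of > 100000 nM in this assay, at which 2 of the 4 values shown sit. Against cyano on the aromatic carbon, 2-hydroxyethyl still gives a 4.7-fold higher number from compound 2 to compound 4 (0.67 log units; beyond the scatter), so more of compound 4 is tolerated than of compound 2.

On these data alone, whether an amine, a carboxylic acid or a longer chain in place of hydroxymethyl would shift the number stays open. The step between the two limits cannot be read.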